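A few compounds are considered here, and "the series" means these few. Any claim that something is new, unique, unknown or untested is made for them only; others in the source may bear on it.

Measured compounds and their values in an assay on LtK cells with ATP-sensitive inward rectifier potassium channel 11 (Homo sapiens) as the target; on this read-out higher numbers stand for an effect only at larger amounts of compound and lower numbers for an effect already at smaller amounts:

- compound 1, `CCC(C)C(=O)Nc1c(C(O)(C(F)(F)F)C(F)(F)F)ccc2ccccc12`: 177000 nM
- compound 2, `O=C(CC1CCCC1)Nc1c(C(O)(C(F)(F)F)C(F)(F)F)ccc2ccccc12`: 81 nM
- compound 3, `O=C(Nc1c(C(O)(C(F)(F)F)C(F)(F)F)ccc2ccccc12)c1cccc(Br)c1`: 80 nM

Compound 3 gives the lowest of the three numbers in this assay, but its value and that of compound 2 sit within the scatter of each other, as the step of a 1.0-fold lower number from compound 2 to compound 3 (0.01 log units; within the scatter) shows. Compound 1 stands far apart: the steps of a 2200-fold lower number from compound 1 to compound 2 (3.34 log units; beyond the scatter) and a 2200-fold lower number from compound 1 to compound 3 (3.34 log units; beyond the scatter) are both large, so the sec-butyl amide is the odd one out, while the cyclopentylmethyl and 3-bromophenyl amides are indistinguishable here.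

Compound 4, `COc1ccc(C(=O)Nc2c(C(O)(C(F)(F)F)C(F)(F)F)ccc3ccccc23)cc1`, has not been measured. It differs from compound 3 in one place: 4-methoxyphenyl in place of 3-bromophenyl on a carbonyl carbon. Within the data shown here, no measured step exchanges one aryl group for another, so the only guide is that swapping 3-bromophenyl for a quite different group, cyclopentylmethyl, left this assay unchanged in a 1.0-fold lower number from compound 2 to compound 3 (0.01 log units; within the scatter). On that basis the step of a 1.9-fold higher number from compound 3 to compound 4 (0.27 log units; within the scatter) is expected to stay within or only slightly beyond the scatter. Compound 4 is therefore estimated at 150 nM in this assay, with a range from 40 nM to 600 nM.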

Compound 4, half-maximal effective concentration: 417 nM
Estimate against measurement, compound 4: 2.8-fold (0.44 log units) below, within the range that was stated.
By their numbers in this assay, from the lowest: compounds 3 and 2 (each within the scatter of the next); then compound 4; then compound 1.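

Among the aryl amides, the group on this carbonyl carbon does make a difference in this assay (a 5.2-fold higher number from compound 3 to compound 4 (0.72 log units; beyond the scatter)), so the match between 3-bromophenyl and cyclopentylmethyl does not extend to 4-methoxyphenyl. The gap to cyclopentylmethyl is of similar size (a 5.1-fold higher number from compound 2 to compound 4 (0.71 log units; beyond the scatter)), yet 4-methoxyphenyl stays far from sec-butyl (a 420-fold lower number from compound 1 to compound 4 (2.63 log units; beyond the scatter)), so the values at this position no longer fall into just two groups. The change swaps bromine for oxygen, adds the hydrogen-bond acceptor counted for 4-methoxyphenyl and alters the ring's substitution all at once, and nothing available here bears on which of these matters.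

The 3-methoxyphenyl and 4-bromophenyl amides would separate the identity of the ring substituent from its place on the ring. As far as these compounds go, how an amine or a carboxylic acid on that ring would read remains open.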